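The source may report more compounds than this note shows. Statements on the series, on what has been measured and on what is new or still open speak of the compounds shown alone.

Compound 1 `COCCC1=C(N2CC2)C(=O)C(C)=C(N2CC2)C1=O`: 5.42 in a functional assay on L1210 cells (Mus musculus), with a stated time of 12 days; a lower number here means a less potent compound, a higher number a more potent compound, by a factor of ten per unit of this negative logarithm
Compound 2 `CC1=C(N2CC2)C(=O)C(CCCc2ccccc2)=C(N2CC2)C1=O`: 4.21

Compound 1 stands highest of the two numbers, with compound 2 giving a number 1.21 log units lower from compound 1 to compound 2 (beyond the scatter). Compound 3 `CC1=C(N2CC2)C(=O)C(N2CC2)=C(N2CC2)C1=O` carries aziridin-1-yl in place of 2-methoxyethyl on a double-bonded ring carbon. Among the measured compounds shown here, the only measured step changes a different part of the chain, a benzyl in place of a methoxy, and that step was large and downward; it does not bear directly on exchanging the whole 2-methoxyethyl for aziridin-1-yl, so no direction is established. The change is expected to stay within the scatter, giving a number 0.12 log units lower from compound 1 to compound 3 (within the scatter). Compound 3 is therefore estimated at 5.3, within 4.6 to 6.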

Compound 3, logarithm of the reciprocal of the active concentration, log(1/C): 6.21
The estimate for compound 3 lay 0.91 log units below the measured number; the measured number lies above the stated range.
By their numbers in this assay, from the lowest: compound 2; then compound 1; then compound 3.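

Exchanging 2-methoxyethyl for aziridin-1-yl on this double-bonded ring carbon raises the number in this assay, giving a number 0.79 log units higher from compound 1 to compound 3 (beyond the scatter). Among the compounds shown here, this position therefore responds when the whole group is exchanged, and a third aziridin-1-yl group on the core goes with the highest number so far. No measurement here accounts for the rise. Open, going by these compounds, is whether the three-membered ring matters or the nitrogen alone: a dimethylamino group at this position would separate the two. Also open, on these data alone, is whether a plain ethyl chain here would match compound 1, which would show what its methoxy contributes.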